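The source may hold more compounds than are shown below. What is called first, only, known or untested is meant among the compounds shown, and "the series" means these compounds.

Compound 3 `Cc1ccc(OCC2CCC2)cc1-c1cccc(COc2ccc(OCC(=O)O)c(F)c2)c1` gives 1530 nM in a functional assay on CHO cells for agonist activity at Free fatty acid receptor 1 (Homo sapiens), read by FLIPR and calcium flux (on this read-out higher numbers stand for an effect only at larger amounts of compound and lower numbers for an effect already at smaller amounts), the highest of the three numbers in hand. Compound 1 `Cc1ccc(OCC2CCCCC2)cc1-c1cccc(COc2ccc(OCC(=O)O)c(F)c2)c1` with 910 nM sits within the scatter of that value, whereas compound 2 `Cc1ccc(OCC2CCCC2)cc1-c1cccc(COc2ccc(OCC(=O)O)c(F)c2)c1` with 490 nM does not, the gap being a 3.1-fold higher number from compound 2 to compound 3 (0.49 log units; beyond the scatter). Compound 4 `Cc1ccc(OCCC2CCCCC2)cc1-c1cccc(COc2ccc(OCC(=O)O)c(F)c2)c1` differs from compound 3 by cyclohexylmethyl in place of cyclobutyl on a saturated chain carbon bound to an oxygen on an aromatic ring. Going by the values given here, no measured step matches this change exactly; the nearest are a 1.7-fold higher number from compound 1 to compound 3 (0.23 log units; within the scatter) and a 1.9-fold lower number from compound 1 to compound 2 (0.27 log units; within the scatter), both within the scatter, and only a 3.1-fold higher number from compound 2 to compound 3 (0.49 log units; beyond the scatter) exceeds it. Going back to a six-membered non-aromatic ring, now carried on a longer chain, is therefore expected to give no more than a modest shift, with a 1.9-fold lower number from compound 3 to compound 4 (0.28 log units; within the scatter) pointing toward a lower number. Compound 4 is estimated at 800 nM, expected to fall between 300 nM and 2500 nM.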

Compound 4, half-maximal effective concentration: 520 nM
For compound 4 the middle estimate is 1.5-fold (0.19 log units) above the measured one; the measured number falls inside the stated range.
By their numbers in this assay, from the lowest: compounds 2, 4, 1 and 3 (each within the scatter of the next, the first and the last beyond it).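

The 2-cyclohexylethoxy group clears the scatter against the cyclobutylmethoxy group of compound 3 (a 2.9-fold lower number from compound 3 to compound 4 (0.47 log units; beyond the scatter)). It remains level with both the cyclopentyl and cyclohexyl analogues (a 1.1-fold higher number from compound 2 to compound 4 (0.03 log units; within the scatter); a 1.8-fold lower number from compound 1 to compound 4 (0.24 log units; within the scatter)), so adding a chain carbon to the six-membered ring brings no step beyond the scatter at this position. Nothing available explains these differences.

The compounds shown leave open whether a longer chain, such as 3-cyclohexylpropyl, would hold this level. They also leave open how a phenyl ring would compare on the same chain.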